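Chloro to chlorophenyl on a benzimidazole-linked pyrazolone

A few compounds are considered here, and "the series" means these few. Any claim that something is new, unique, unknown or untested is made for them only; others in the source may bear on it.

Measured compounds:
compound 1, `Cc1[nH]n(-c2nc3cc(Cl)ccc3[nH]2)c(=O)c1Cc1ccccc1`, 86%
compound 2, `Cc1ccc2[nH]c(-n3[nH]c(C)c(C)c3=O)nc2c1`, -11%

In a functional assay on DU-145 cells (Homo sapiens) for antiproliferative activity, read by WST assay, with a stated time of 48 h, tested at 1 uM (on this read-out lower numbers stand for a weaker effect and higher numbers for a stronger effect at the one concentration tested), compound 1 gives 86%, the highest of the two numbers. Compound 2 gives -11%, a number far lower and beyond the scatter; the two compounds differ in more than one place, so only their two values can be compared. Compound 3, `Cc1[nH]n(-c2nc3cc(-c4ccc(Cl)cc4)ccc3[nH]2)c(=O)c1Cc1ccccc1`, is not yet measured. It differs from compound 1 in a single place: 4-chlorophenyl in place of chloro on an aromatic carbon. Among the compounds with values here, no step between two measured compounds informs this change, so the expectation rests on compound 1 alone, whose value of 86% leaves little room upward. The step from compound 1 to compound 3 is expected to be small, a number 6 percentage points lower from compound 1 to compound 3 (within the scatter), likely within the scatter. Compound 3 is therefore estimated at 80%, in a range from 50% to 95%.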

Compound 3, a percentage reported as inhibition, at one concentration (the size of the read-out at that concentration, not a potency): 70%
For compound 3 the middle estimate is 10 percentage points above the measured one; the range from low to high includes it.
By their numbers in this assay, from the lowest: compound 2; then compound 3; then compound 1.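

Within the data shown here, putting 4-chlorophenyl in place of chloro on this aromatic carbon gives the first step at a single place, in this assay: a number 16 percentage points lower from compound 1 to compound 3 (beyond the scatter). The larger group, which brings one more six-membered aromatic ring, lowers the effect without removing it, as compound 3 still reaches 70% at the one concentration tested. Nothing in the data accounts for this drop.

The compounds shown leave open how an amine or a carboxylic acid would read at this aromatic carbon, and whether an unsubstituted phenyl would fall nearer to chloro or to 4-chlorophenyl. As the read-out comes from one concentration, they also leave open how compound 1 and compound 3 compare in potency.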